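This account rests on a few compounds, and the source may have more. Where it says the series, first, only, none or still open, it means among the compounds named here.

Compound 1 `Cc1oc(-c2ccc(F)cc2)nc1CN1CCC(C(=O)NCCCN2C[C@H](C)C[C@H](C)C2)CC1`: 0.468 h
Compound 2 `Cc1ccccc1-c1nc(CN2CCC(C(=O)NCCCN3CCCCC3)CC2)c(C)o1`: > 0.5 h

In an ADME assay on microsomes from liver (Rattus norvegicus) for metabolic stability, read by LC-MS, using NADPH, at 37 degrees C (a higher number here means that the compound lasts longer, a lower number that the compound disappears faster), compound 1 gives 0.468 h. Compound 2 gives > 0.5 h in this assay, and that figure is a limit of the assay rather than a number; it sits at the limit of > 0.5 h in this assay, at which 1 of the 2 values shown sits. So compound 2 stands at the edge of what this assay reports, and where it truly lies is known only as a range. Compound 3 `CCCN(CCC)CCNC(=O)C1CCN(Cc2nc(-c3ccccc3C)oc2C)CC1` has not yet been measured. It differs from compound 2 by dipropylamino in place of (piperidin-1-yl)methyl on a saturated chain carbon, two bonds along the chain from an amide-type nitrogen. Among the compounds with values here, no measured pair shows a change of this kind, so the size of the step cannot be read from the data. The expectation is a step of a number no higher from compound 2 to compound 3 (the limit leaves the size open), nothing beyond the scatter. Compound 3 is therefore estimated at 0.5 h, with a range from 0.28 h to 0.9 h, and it may well be that this assay once more reports only a limit.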

Compound 3, half-life: > 0.5 h
Compound 3: only a limit was reported (the forecaster's own chance of this, stated with the estimate: 50%); the middle value lies on the limit itself.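

Within the data shown here, compound 2 and compound 3 both give only a limit in this assay and not a number, so no step between them can be read. Still open, as far as these compounds go, is how long each truly lasts, and whether dipropylamino in place of (piperidin-1-yl)methyl changes that at all.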